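The source may hold more compounds than are shown below. What is called first, only, known or untested is meant among the compounds shown, and "the series" means these compounds.

Measured so far in an assay for binding affinity to adenosine receptor A1 (Rattus norvegicus), in the presence of a further agent that is not named here; on this read-out lower numbers stand for stronger inhibition and higher numbers for weaker inhibition:

- compound 1, `Cn1c(=O)[nH]c2cc[nH]c2c1=O`: 2900 nM
- compound 2, `Cn1c(=O)c2c(ccn2C)n(C)c1=O`: 32000 nM

Compound 2 stands at the highest number of the two, and the gap to compound 1 is beyond the usual scatter of this assay, so compound 1 inhibits more strongly. Going by the values given here, no pair that differs in a single place has been measured, so no step size for any given change is known.

Compound 3, `Cn1c(=O)c2c(cc(-c3ccccc3)n2C)n(C)c1=O`, is the next compound to be measured. It differs from compound 2 by phenyl in place of hydrogen on an aromatic carbon — phenyl in place of hydrogen on an aromatic carbon. Nothing in the two measured compounds shows what this change does; the expectation below is an estimate from the change alone. A large group enters where compound 2 carries only a hydrogen, and the expectation is that the number falls rather than rises, by a step beyond the scatter, though the size is uncertain.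

Compound 3 is expected to give about 3000 nM, within 400 nM to 25000 nM, which would mean an estimated step of an 11-fold lower number from compound 2 to compound 3 (1.03 log units; beyond the scatter).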

Compound 3, inhibition constant: 3600 nM
For compound 3 the middle estimate is 1.2-fold (0.08 log units) below the measured one; measured number inside the range.
By their numbers in this assay, from the lowest: compounds 1 and 3 (each within the scatter of the next); then compound 2.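

In this assay, going by these compounds alone, the aromatic carbon next to the ring nitrogen and next to the ring atom that bears a methyl group tolerates far more than a hydrogen: phenyl at this position gives an 8.9-fold lower number from compound 2 to compound 3 (0.95 log units; beyond the scatter), the first step that can be tied to a single change. The entering phenyl adds 6 heavy atoms, all carbon, with 0 hydrogen-bond donors and 0 hydrogen-bond acceptors, so for this one change a lower number is reached without a donor or acceptor on the new group. Nothing available accounts for why the number falls at this position.

As far as these compounds go, it remains open whether the step belongs to phenyl itself or would also appear with a smaller group such as methyl, or with a phenyl carrying a hydroxyl or an amine. From the compounds shown here alone, it is equally open whether phenyl at the same position on the core of compound 1 would give a step of similar size.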